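This account rests on a few compounds, and the source may have more. Where it says the series, first, only, none or still open, it means among the compounds named here.

Of the compounds shown here, three have so far been tested in an ADME assay on RAW264.7 cells (Mus musculus) for cytotoxicity, read by MTT assay, with a stated time of 24 h, tested at 1.25 ug/mL; on this read-out higher numbers stand for a weaker effect at the one concentration tested and lower numbers for a stronger effect. Compound 1 `COc1ccc(CCC(=O)c2cccc(O)c2)cc1` gives 97.5% in this assay. Compound 2 `COc1ccc(CCCc2ccc(OC)cc2OC)c(O)c1` gives 100%, and compound 3 `COc1ccc(/C=C/C(=O)c2ccc(OC)c(OC)c2)cc1` gives 97.2%. Among these three numbers compound 1 stands second highest; its nearest neighbour is compound 3 and its furthest is compound 2, and both gaps lie within the usual scatter, so the three cannot be told apart on this read-out. All of them leave the cells essentially untouched at the concentration tested.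

Compound 4 `COc1ccc(CCC(=O)c2cccc(O)c2)c(OC)c1` has not yet been measured. It differs from compound 1 in one place: methoxy in place of hydrogen on an aromatic carbon. The new group sits on an aromatic carbon of a six-membered aromatic ring of carbon only, meta to a methoxy group. For the measured compounds named here, no step between two measured compounds is available, so nothing yet shows how such a change moves this assay. Every measured compound sits near no effect, and the expected step is a number 0.5 percentage points higher from compound 1 to compound 4 (within the scatter), none beyond the scatter. For compound 4 the estimate is 98%, with a range from 90% to 104%.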

Compound 4, a percentage reported as activity, at one concentration (the size of the read-out at that concentration, not a potency): 92.1%
Compound 4: middle estimate off by 5.9 percentage points, on the high side; measured number inside the range.
By their numbers in this assay, from the lowest: compounds 4, 3, 1 and 2 (each within the scatter of the next).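

For the compounds shown here, compound 1 and compound 4 form the only pair here that differs in one place, so they give the first direct reading of this change: methoxy in place of hydrogen on an aromatic carbon, ortho to a large group and meta to a methoxy group. In this assay the change gives a number 5.4 percentage points lower from compound 1 to compound 4 (within the scatter), so at this position the added methoxy leaves the cells as close to no effect as the other compounds at the one concentration tested. Nothing measured here bears on the reason for this result.

Going by these compounds, whether an amine, a carboxylic acid or a longer chain such as ethoxy at the same position would behave alike stays open. So does whether methoxy on another carbon of this ring would give a similar reading.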